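Second Trifluoromethyl on the Benzamide of Compound 2

The source may report more compounds than this note shows. Statements on the series, on what has been measured and on what is new or still open speak of the compounds shown alone.

Measured compounds:
compound 1, `COc1cc(Cl)cc(-c2nn(-c3cccc(NC(=O)c4ccc(Cl)c(Cl)c4)c3)cc2-c2ccncc2)c1`, gives 79.2% in a functional assay on OVCAR-5 cells (Homo sapiens) for inhibition, read by sulforhodamine B assay, with a stated time of 48 h, tested at 10 uM; on this read-out higher numbers stand for a weaker effect at the one concentration tested and lower numbers for a stronger effect
compound 2, `COc1cc(Cl)cc(-c2nn(-c3cccc(NC(=O)c4cccc(C(F)(F)F)c4)c3)cc2-c2ccncc2)c1`, gives 84.1% in this assay

Both compounds share the same core and differ only in the aryl group on the carbonyl carbon. The one step that has been measured, a number 4.9 percentage points higher from compound 1 to compound 2 (within the scatter), lies within the scatter, so on the numbers shown compound 2 and compound 1 cannot be told apart; compound 2 stands alongside compound 1 rather than above or below it.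

Compound 3, `COc1cc(Cl)cc(-c2nn(-c3cccc(NC(=O)c4cc(C(F)(F)F)cc(C(F)(F)F)c4)c3)cc2-c2ccncc2)c1`, has not yet been measured. It differs from compound 2 by trifluoromethyl in place of hydrogen on an aromatic carbon.

Going by the values given here, only the step from compound 1 to compound 2 bears on this change, and it was within the scatter. Nothing in the data suggests that adding a second trifluoromethyl group should move the read-out beyond the scatter. Compound 3 is therefore expected to give about 85% in this assay, between 70% and 98%, a step of a number 0.9 percentage points higher from compound 2 to compound 3 (within the scatter) that is estimated to stay within the usual scatter.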

Compound 3, a percentage reported as activity, at one concentration (the size of the read-out at that concentration, not a potency): 83%
The estimate for compound 3 lay 2 percentage points above the measured number; low and high end bracket the measured number.
By their numbers in this assay, from the lowest: compounds 1, 3 and 2 (each within the scatter of the next).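

Trifluoromethyl in place of hydrogen on an aromatic carbon of the six-membered aromatic ring, meta to a trifluoromethyl group, comes with a number 1.1 percentage points lower from compound 2 to compound 3 (within the scatter) in this assay, so compound 2 and compound 3 cannot be told apart on this read-out. Going by these compounds alone, the earlier step exchanged one aryl group for another on the carbonyl carbon, whereas this one adds 4 heavy atoms to a ring that already carries a trifluoromethyl group, and the added bulk of atoms leaves no step that can be read beyond the scatter. Nothing measured on these compounds offers a reason for this outcome.

From the compounds shown here alone, whether a different kind of group at this position, such as an amine or a carboxylic acid, would give a number beyond the scatter of compound 2 remains open. The compounds shown also share the same core and vary only in the aryl group on the carbonyl carbon, so they say nothing about replacing the amide itself or the methoxy group on the core.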